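Swapping a Fluorophenyl for a Methoxyphenylamino Group

The source may report more compounds than this note shows. Statements on the series, on what has been measured and on what is new or still open speak of the compounds shown alone.

compound 1, `CCc1ccccc1N(Cc1nnc(Cc2ccc(Cl)cc2)o1)S(=O)(=O)c1ccc(C)cc1`: in a functional assay on CHO cells for antagonist activity at prostaglandin E2 receptor EP1 subtype (Homo sapiens), read by FLIPR and calcium flux (on this read-out lower numbers stand for stronger inhibition and higher numbers for weaker inhibition), compound 1 gives 316 nM
compound 2, `COc1ccc(Cc2nnc(CN(c3cccc(Cl)c3C)S(=O)(=O)c3ccc(C)cc3)o2)cc1`: compound 2 gives 39.8 nM
compound 3, `Cc1ccc(S(=O)(=O)N(Cc2nnc(Cc3cccc(F)c3)o2)c2cccc(Cl)c2C)cc1`: compound 3 gives 501 nM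

Compound 3 shows the highest of the three numbers, with compound 1 close by within the scatter and compound 2 far lower. Compound 4 `COc1ccc(NCc2nnc(CN(c3cccc(Cl)c3C)S(=O)(=O)c3ccc(C)cc3)o2)cc1` is unmeasured; it carries (4-methoxyphenyl)amino in place of 3-fluorophenyl on a saturated chain carbon bound to an aromatic carbon. Among the measured compounds shown here, the one measured step at this position, a 13-fold higher number from compound 2 to compound 3 (1.10 log units; beyond the scatter), exchanged the same two aryl groups, and compound 4 differs from compound 2 only by the added amino link, for which no step is measured. Reversing that large step suggests a strong drop in the number, expected as an 8.4-fold lower number from compound 3 to compound 4 (0.92 log units; beyond the scatter). Compound 4 is therefore estimated at 60 nM, in the range 20 nM to 200 nM.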

Compound 4, inhibition constant: 79.4 nM
For compound 4 the middle estimate is 1.3-fold (0.12 log units) below the measured one, within the range that was stated.
By their numbers in this assay, from the lowest: compounds 2 and 4 (each within the scatter of the next); then compounds 1 and 3 (each within the scatter of the next).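

Moving to the (4-methoxyphenyl)amino group gives a 6.3-fold lower number from compound 3 to compound 4 (0.80 log units; beyond the scatter) on this saturated chain carbon, so the 4-methoxyphenyl ring keeps its advantage over 3-fluorophenyl even with an amino link added. That link leaves only a 2.0-fold higher number from compound 2 to compound 4 (0.30 log units; within the scatter) as its trace, which means compound 2 and compound 4 cannot be told apart here. No measurement shown explains these results.

As far as these compounds go, it remains open whether a longer chain or an ether oxygen in place of the amino link would hold the number at this position. Also open, from the compounds shown here alone, is whether the methoxy group alone accounts for the difference from 3-fluorophenyl.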